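This account rests on a few compounds, and the source may have more. Where it says the series, first, only, none or still open, it means among the compounds named here.

Working notes on the series, all read in a functional assay on DU-145 cells (Homo sapiens) for inhibition, read by trypan blue exclusion, with a stated time of 96 h; on this read-out higher numbers stand for weaker inhibition of growth and lower numbers for stronger inhibition of growth. Compound 1 `CC(=O)Oc1ccc(/C=C(\C(=O)c2ccc(Cl)cc2)S(=O)(=O)c2ccc(C)cc2)cc1` gives 25000 nM in this assay, and compound 2 `Cc1ccc(S/C(=C/c2ccc(Cl)c(Cl)c2)C(=O)c2ccc(Br)cc2)cc1` gives 50000 nM. Compound 1 holds the lower of the two numbers, but the two lie within the scatter of each other, so no order between them can be claimed. Compound 3 `Cc1ccc(S(=O)(=O)/C(=C/c2sccc2C)C(=O)c2ccc(Cl)cc2)cc1` is not yet measured; it differs from compound 1 by 3-methylthiophen-2-yl in place of 4-acetoxyphenyl on a double-bonded chain carbon bound to a double-bonded chain carbon. Within the data shown here, no measured pair isolates such a change, so the step is expected to be a 1.2-fold higher number from compound 1 to compound 3 (0.08 log units; within the scatter), nothing beyond the scatter in either direction. Compound 3 is therefore estimated at 30000 nM, with a range from 10000 nM to 90000 nM.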

Compound 3, concentration for 50% growth inhibition: 10000 nM
Compound 3: the middle estimate sits 3.0-fold (0.48 log units) above what was measured; measured number inside the range.
By their numbers in this assay, from the lowest: compound 3; then compounds 1 and 2 (each within the scatter of the next).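

In this assay, among these compounds, the position on a double-bonded chain carbon bound to a double-bonded chain carbon responds to the group it carries: 3-methylthiophen-2-yl in place of 4-acetoxyphenyl gives a 2.5-fold lower number from compound 1 to compound 3 (0.40 log units; beyond the scatter) and marks the first step beyond the scatter. The 4-acetoxyphenyl group is therefore not required here for growth inhibition. Nothing at hand explains the step.

From the compounds shown here alone, it remains open whether the step belongs to the thiophene ring or to its methyl group. Going by these compounds, how an unsubstituted thiophen-2-yl or a 4-aminophenyl group would read at this position also remains open.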